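Dimethoxyphenyl in Place of Diethylaminophenyl on the Amide

This account rests on a few compounds, and the source may have more. Where it says the series, first, only, none or still open, it means among the compounds named here.

Three compounds sharing one core have been measured in an in vitro assay on Sf21 cells for inhibition of high affinity 3',5'-cyclic-AMP phosphodiesterase 7A (Homo sapiens), read by scintillation proximity assay, with a stated time of 30 min; on this read-out higher numbers stand for weaker inhibition and lower numbers for stronger inhibition:

Compound 1, `CCN(CC)c1ccc(NC(=O)c2cn(Cc3c(F)cccc3F)c3ccc(=O)[nH]c3c2=O)cc1`, gives 46 nM.
Compound 2, `O=C(Nc1ccccc1)c1cn(Cc2c(F)cccc2F)c2ccc(=O)[nH]c2c1=O`, gives 94 nM.
Compound 3, `NS(=O)(=O)c1ccc(NC(=O)c2cn(Cc3c(F)cccc3F)c3ccc(=O)[nH]c3c2=O)cc1`, gives 34 nM.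

Compound 1 holds the second highest number of the three. Its nearest neighbour is compound 3, with a 1.4-fold lower number from compound 1 to compound 3 (0.13 log units; within the scatter), so these two cannot be told apart. Its furthest is compound 2, with a 2.0-fold higher number from compound 1 to compound 2 (0.31 log units; beyond the scatter). The third step, a 2.8-fold lower number from compound 2 to compound 3 (0.44 log units; beyond the scatter), shows that changing the group on the phenyl ring attached to the amide shifts the number modestly at most.

Compound 4, `COc1cc(NC(=O)c2cn(Cc3c(F)cccc3F)c3ccc(=O)[nH]c3c2=O)cc(OC)c1`, is not yet measured. It differs from compound 1 in one place: 3,5-dimethoxyphenyl in place of 4-(diethylamino)phenyl on an amide-type nitrogen. For the measured compounds named here, no measured pair shows this exact swap, so the two steps above are the only guide; both are modest, and both concern this same ring. A small step in either direction, or none beyond the scatter, is therefore expected for compound 4, roughly a 1.3-fold higher number from compound 1 to compound 4 (0.12 log units; within the scatter). Compound 4 is estimated at 60 nM, with a range from 22 nM to 160 nM.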

Compound 4, half-maximal inhibitory concentration: 212 nM
The estimate for compound 4 lay 3.5-fold (0.55 log units) below the measured number, outside the stated range (above it).
By their numbers in this assay, from the lowest: compounds 3 and 1 (each within the scatter of the next); then compound 2; then compound 4.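

In this assay, 3,5-dimethoxyphenyl on the amide-type nitrogen is the only group shown that gives a higher number than plain phenyl, with a 2.3-fold higher number from compound 2 to compound 4 (0.35 log units; beyond the scatter) and so a weaker result. The distance grows against the two other substituted rings, with a 4.6-fold higher number from compound 1 to compound 4 (0.66 log units; beyond the scatter) and a 6.2-fold higher number from compound 3 to compound 4 (0.79 log units; beyond the scatter) in this set. Compounds 1 and 3 go the other way from compound 4 relative to compound 2, so adding groups to this ring does not shift the number in one fixed direction, and no measurement available here explains the difference.

The entering ring differs from the others in both the identity and the placement of its groups, so these two changes cannot be separated. A ring carrying a single methoxy group would help to separate them, while an amine or a carboxylic acid on the ring remains an open comparison.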